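Replacing Carbamoyl with Oxan-4-yl on an Amine Nitrogen

This account rests on a few compounds, and the source may have more. Where it says the series, first, only, none or still open, it means among the compounds named here.

- Compound 1 `NCCCCN(C[C@@H]1Cc2ncccc2CN1)[C@H]1CCCc2cccnc21`: 2 nm/s
- Compound 2 `NCCCCN(C[C@@H]1Cc2cccnc2CN1)[C@H]1CCCc2cccnc21`: "not determined" (no result reported)
- Compound 3 `NC(=O)NCCCCN(C[C@H]1Cc2ncccc2CN1)[C@H]1CCCc2cccnc21`: 7 nm/s

In an ADME assay for permeability, using PAMPA, with a stated time of 4 h, at pH 5.5 (a higher number here means that the compound crosses the layer faster, a lower number that the compound crosses the layer more slowly), compound 3 gives 7 nm/s, the highest of the two numbers available. Compound 1 gives 2 nm/s. The gap between these two numbers lies beyond the scatter. Compound 2 has no number to compare.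

Compound 4 `c1cnc2c(c1)CN[C@@H](CN(CCCCNC1CCOCC1)[C@H]1CCCc3cccnc31)C2` has not yet been measured. It carries oxan-4-yl in place of carbamoyl on an amine nitrogen. Within the data shown here, no measured pair in this small set shows a change of this kind, so any expectation is loose. Like compound 1, which gives 2 nm/s, compound 4 lacks the carbamoyl group, and this is the only guide available. A downward move of modest size is therefore expected, and the estimated step is a 2.3-fold lower number from compound 3 to compound 4 (0.37 log units; beyond the scatter). For compound 4 the estimated value is 3 nm/s, with an expected range of 1 nm/s to 8 nm/s.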

Compound 4, apparent permeability: 2 nm/s
Estimate against measurement, compound 4: 1.5-fold (0.18 log units) above, and the stated range covers the measured number.
By their numbers in this assay, from the lowest: compounds 1 and 4 (each within the scatter of the next); then compound 3.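

On an amine nitrogen whose other neighbour is a saturated chain carbon, this assay shows a 3.5-fold lower number from compound 3 to compound 4 (0.54 log units; beyond the scatter) when oxan-4-yl takes the place of carbamoyl. This gives the set its first comparison of two compounds that differ in one place, and it shows that this position responds to the change by more than the scatter. The single step cannot separate the loss of the carbamoyl hydrogen-bond donor from the arrival of the six-membered non-aromatic ring, and no measurement shown explains it.

From the compounds shown here alone, it remains open whether an acetyl group, a methyl group or a carboxylic acid at this nitrogen would give a number nearer to that of compound 3 or compound 4. Going by these compounds, it also remains open whether a smaller ring such as oxetan-3-yl would follow oxan-4-yl.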